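The source may hold more compounds than are shown below. What is called first, only, known or untested is meant among the compounds shown, and "the series" means these compounds.

In a functional assay on HCT-116 cells (Homo sapiens) for cytotoxicity, read by MTT assay, with a stated time of 72 h (a lower number here means a stronger inhibitor, a higher number a weaker inhibitor), compound 1 (`CC(C)C[S+]([O-])CCCCN=C=S`) gives 2060 nM and compound 2 (`[O-][S+](CCCCN=C=S)Cc1cccs1`) gives 3210 nM. For the measured compounds named here, the step between these two is a 1.6-fold higher number from compound 1 to compound 2 (0.19 log units; within the scatter), so compound 2 cannot be ranked apart from the only other measured compound. Compound 3 (`[O-][S+](CCCCN=C=S)Cc1ccco1`) has not yet been measured in this assay. Its structure departs from that of compound 2 at a single place: furan-2-yl in place of thiophen-2-yl on a saturated chain carbon bound to a sulfur. Put simply, this is furan-2-yl in place of thiophen-2-yl on a saturated chain carbon bound to a sulfur. Going by the values given here, only one measured step bears on this change, as it concerns the same place. Going to compound 2 from compound 1 put thiophen-2-yl in place of isopropyl, and that step, a 1.6-fold higher number from compound 1 to compound 2 (0.19 log units; within the scatter), was small. Among the compounds with values here, with only this evidence, and with one five-membered aromatic ring replacing another, nothing beyond the scatter is expected. The estimated step is a 1.1-fold lower number from compound 2 to compound 3 (0.03 log units; within the scatter). For compound 3 the expected value is 3000 nM, with an estimated range of 1400 nM to 6500 nM.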

Compound 3, half-maximal inhibitory concentration: 3470 nM
Estimate against measurement, compound 3: 1.2-fold (0.06 log units) below; low and high end bracket the measured number.
By their numbers in this assay, from the lowest: compounds 1, 2 and 3 (each within the scatter of the next).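

In this assay, furan-2-yl in place of thiophen-2-yl on a saturated chain carbon bound to a sulfur gives a 1.1-fold higher number from compound 2 to compound 3 (0.03 log units; within the scatter), so exchanging the one hetero atom of this five-membered aromatic ring, sulfur for oxygen, makes no difference that can be read in this assay. Furan-2-yl in place of isopropyl gives a 1.7-fold higher number from compound 1 to compound 3 (0.23 log units; within the scatter), and with the earlier 1.6-fold higher number from compound 1 to compound 2 (0.19 log units; within the scatter) this means that neither of the two aromatic rings can be told apart from isopropyl at this position, which now holds three different groups with no separation among them. No measured evidence is available that could explain why these groups fall so closely together.

The groups shown are limited to isopropyl and two five-membered aromatic rings, so it remains open whether an amine, a carboxylic acid or a phenyl ring at this place would move the number beyond the scatter. On these data alone, it also remains open whether a longer chain in the shared core would leave these three groups just as hard to separate.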